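Thiophene for Benzofuran on Two Nucleoside Cores

The source may report more compounds than this note shows. Statements on the series, on what has been measured and on what is new or still open speak of the compounds shown alone.

Of the compounds shown here, three have been measured in a functional assay on A549 cells (Homo sapiens), read by MTT assay, with a stated time of 72 h; a higher number here means a weaker inhibitor, a lower number a stronger inhibitor: compound 1 `O=c1[nH]cnc2c1c(-c1ccsc1)cn2[C@@H]1O[C@H](CO)[C@@H](O)[C@H]1O`, compound 2 `O=c1[nH]cnc2c1c(-c1cc3ccccc3o1)cn2[C@@H]1O[C@H](CO)[C@@H](O)[C@H]1O` and compound 3 `Cc1nc(N)c2c(-c3cc4ccccc4o3)cn([C@@H]3O[C@H](CO)[C@@H](O)[C@H]3O)c2n1`. Compound 1 gives only a limit of the assay, > 20000 nM. Compound 2 likewise gives a limit, > 20000 nM. Compound 3 too rests at a limit, > 20000 nM. The change from compound 2 to compound 1 is thiophen-3-yl in place of 1-benzofuran-2-yl on an aromatic carbon; its step that the two limits leave unreadable from compound 2 to compound 1 cannot be read because of the limit of > 20000 nM in this assay, at which 3 of the 3 values shown sit. Compound 4 `Cc1nc(N)c2c(-c3ccsc3)cn([C@@H]3O[C@H](CO)[C@@H](O)[C@H]3O)c2n1` has not yet been measured; it differs from compound 3 by the same change, (thiophen-3-yl in place of 1-benzofuran-2-yl on an aromatic carbon), while the difference between the cores of compound 2 and compound 3 is not broken down here. With the earlier step unreadable, the step expected from compound 3 to compound 4 is a step that the limit leaves unreadable from compound 3 to compound 4, again at the limit. Compound 4 is therefore estimated at 30000 nM in this assay.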

Compound 4, half-maximal inhibitory concentration: > 20000 nM
Compound 4 gave a limit, no number (the forecaster's own chance of this, stated with the estimate: 90%); the middle value lies beyond the limit too.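

Compound 4, like compound 3, rests at a limit, so no new step between them can be read, because of this: the limit of > 20000 nM in this assay, at which 4 of the 4 values shown sit.

The compounds shown leave open how thiophen-3-yl and 1-benzofuran-2-yl compare in this assay, since no compound yields an actual number.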